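This account rests on a few compounds, and the source may have more. Where it says the series, first, only, none or still open, it means among the compounds named here.

In a functional assay on MCF7 cells (Homo sapiens) for inhibition, with a stated time of 48 h (a lower number here means a stronger inhibitor, a higher number a weaker inhibitor), compound 1 `CCOc1ccc2[nH]cc(Sc3cc(OC)c(OC)c(OC)c3)c2c1` gives 16 nM, while compound 2 `COc1cc(Sc2c[nH]c3ccc(OCCO)cc23)cc(OC)c1OC` gives 95 nM, the higher of the two numbers. Compound 3 `COc1cc(Sc2c[nH]c3ccc(OCCOCc4ccccc4)cc23)cc(OC)c1OC` differs from compound 2 by benzyl in place of hydrogen on an oxygen on a saturated carbon. Among the measured compounds shown here, only one measured step bears on this chain: a 5.9-fold higher number from compound 1 to compound 2 (0.77 log units; beyond the scatter), a modest change. For the measured compounds named here, it adds a hydroxy rather than a benzyl, so it guides the expected size only loosely, and no measured compound carries a benzyl. A modest move toward a higher number is expected, with an estimated 2.3-fold higher number from compound 2 to compound 3 (0.36 log units; beyond the scatter). For compound 3 the estimated value is 220 nM, with an expected range of 50 nM to 900 nM.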

Compound 3, half-maximal inhibitory concentration: 260 nM
For compound 3 the middle estimate is 1.2-fold (0.07 log units) below the measured one; the measured number falls inside the stated range.
By their numbers in this assay, from the lowest: compound 1; then compound 2; then compound 3.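

In this assay the change from 2-hydroxyethyl to 2-(benzyloxy)ethyl gives a 2.7-fold higher number from compound 2 to compound 3 (0.44 log units; beyond the scatter) and so shows that the number still moves when the hydrogen on that oxygen is replaced. Benzyloxy in place of hydrogen on the saturated chain carbon gives a 16-fold higher number from compound 1 to compound 3 (1.21 log units; beyond the scatter) and exceeds the rise seen with hydroxy at the same place. No evidence at hand accounts for these steps.

Open, as far as these compounds go, is whether a methyl on that oxygen would give a similar step to benzyl. Also open, from the compounds shown here alone, is how an amine, a carboxylic acid or a longer chain would read at this position.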